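Dropping the sulfanyl arm of compound 1: an expected loss

A few compounds are considered here, and "the series" means these few. Any claim that something is new, unique, unknown or untested is made for them only; others in the source may bear on it.

Compound 1 `Cc1cc(Nc2ccc(C(=O)/C=C/c3cccc(Br)n3)cc2)n2nc(SCc3ccccc3[N+](=O)[O-])nc2n1` is the higher of the two numbers in hand: in a functional assay on MGC-803 cells (Homo sapiens) for inhibition, read by sulforhodamine B assay, with a stated time of 72 h, tested at 10 uM (a higher number here means more inhibition at the concentration tested (going by the name of the read-out), a lower number less inhibition), compound 1 gives 92.3%, while compound 2 `Cc1cc(Nc2cc(-c3ccccc3)[nH]n2)n2nc(SCc3nc4ccccc4[nH]3)nc2n1` gives 78.4%, a gap beyond the scatter. Compound 3 `Cc1cc(Nc2ccc(C(=O)/C=C/c3cccc(Br)n3)cc2)n2ncnc2n1` differs from compound 1 by hydrogen in place of (2-nitrobenzyl)sulfanyl on an aromatic carbon on the shared core. Going by the values given here, no measured pair isolates this change, so its size is unknown; removing a group of this size is expected to cost inhibition, giving a downward step a number 32.3 percentage points lower from compound 1 to compound 3 (beyond the scatter) beyond the scatter. Compound 3 is therefore estimated at 60%, with a range from 25% to 85%.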

Compound 3, a percentage reported as inhibition, at one concentration (the size of the read-out at that concentration, not a potency): 58.4%
Estimate against measurement, compound 3: 1.6 percentage points above, and the stated range covers the measured number.
By their numbers in this assay, from the lowest: compound 3; then compound 2; then compound 1.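

Going by these compounds alone, replacing (2-nitrobenzyl)sulfanyl with hydrogen on this aromatic carbon gives in this assay the first step that isolates this position: a number 33.9 percentage points lower from compound 1 to compound 3 (beyond the scatter). Even without the arm, compound 3 gives 58.4% at the concentration tested, so the arm adds to the inhibition but is not required for it. Nothing available explains the size of this step.

Open, going by these compounds, is how much of the step belongs to the nitro group and how much to the rest of the arm. A plain benzylsulfanyl, a methylsulfanyl or an amine on the same carbon would separate these.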